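Does One Fluorine Shift Liver Microsome Stability?

The compounds below may be only part of what the source reports. "The series", "measured", "known", "first", "only" and "open" are said of these compounds alone.

Compound 1 `O=C(O)c1ccc(-n2cc(C(=O)c3c(Cl)cccc3C(F)(F)F)c3cccnc32)c(F)c1` was run in an ADME assay on microsomes from liver (Rattus norvegicus) for metabolic stability, read by LC-MS, using NADPH, with stated times of 5 min and 30 min, tested at 1 uM (a higher number here means that more of the compound is left, a lower number that less of the compound is left), where compound 1 gives 73%. Two relatives were measured the same way. Compound 2 `Cc1cccc(Cl)c1C(=O)c1cn(-c2ccc(C(=O)O)cc2F)c2ncccc12`, carrying a methyl in place of the trifluoromethyl on an aromatic carbon, gives 73%; the step of no change at the digits printed from compound 1 to compound 2 (within the scatter) lies within the scatter. Compound 3 `O=C(O)c1ccc(-n2cc(C(=O)c3c(Cl)cccc3Cl)c3ncccc32)cc1` gives 96%, higher than compound 1 by more than the scatter, but compound 3 differs from compound 1 in more than one place, so no single step can be read from that pair. Compound 1 thus stands level with compound 2, and together they are the lowest of the three numbers.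

Compound 4 `O=C(O)c1ccc(-n2cc(C(=O)c3c(Cl)cccc3C(F)(F)F)c3cccnc32)cc1` differs from compound 1 by one change: hydrogen in place of fluoro on an aromatic carbon. Within the data shown here, the only measured step altered a different group and left the reading unchanged, so it does not speak to this fluoro. Compound 3 also lacks this fluoro and sits higher, yet its other differences blur the comparison. A small upward step a number 7 percentage points higher from compound 1 to compound 4 (within the scatter) is expected, within the scatter. Compound 4 is therefore estimated at 80%, ranging from 62% to 95%.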

Compound 4, percent of the compound remaining: 55%
Estimate against measurement, compound 4: 25 percentage points above; measured number outside the range, below it.
By their numbers in this assay, from the lowest: compound 4; then compounds 1 and 2 (each within the scatter of the next); then compound 3.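

Replacing the fluoro with hydrogen, meta to the carboxy group, gives a number 18 percentage points lower from compound 1 to compound 4 (beyond the scatter) in this assay, so the hydrogen compound has less left and this position is not indifferent to the change. Among these compounds, the only earlier single change, methyl in place of trifluoromethyl at a different place, gave no change at the digits printed from compound 1 to compound 2 (within the scatter), which makes this the first single change here that moves the reading beyond the scatter. Nothing measured here bears on why the fluoro and the higher number go together.

The compounds shown leave open how other groups at this same place, such as a methoxy group or an amine, would compare with fluoro and hydrogen. They also leave open whether the same swap would shift the number by a similar amount in compound 2, which carries the methyl.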